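Adding a second chloro to the halophenyl ring of compound 1

The compounds below may be only part of what the source reports. "The series", "measured", "known", "first", "only" and "open" are said of these compounds alone.

Measured compounds:
compound 1 `COc1cccc(/C=C2\CCC/C(=C\c3ccc(Cl)cc3)C2=O)c1OC` — 11100 nM
compound 2 `COc1cccc(/C=C2\CCC/C(=C\c3ccc(Br)cc3)C2=O)c1OC` — 11100 nM

In a functional assay on SW-620 cells (Homo sapiens) for cytotoxicity, read by MTT assay, with a stated time of 72 h (a lower number here means a stronger inhibitor, a higher number a weaker inhibitor), compound 1 gives 11100 nM, and in the same assay compound 2 gives 11100 nM. Their only difference is bromo in place of chloro on an aromatic carbon, and no change at the digits printed from compound 1 to compound 2 (within the scatter). Compound 1 thus stands level with compound 2. Compound 3 `COc1cccc(/C=C2\CCC/C(=C\c3ccc(Cl)cc3Cl)C2=O)c1OC` differs from compound 1 by chloro in place of hydrogen on an aromatic carbon. For the measured compounds named here, no measured step tells what a chloro entering in place of hydrogen does; the one step known shows that a halogen swap on this ring left potency unchanged. Compound 3 is therefore expected to stay close to compound 1, with a step of a 1.1-fold lower number from compound 1 to compound 3 (0.05 log units; within the scatter). The estimate for compound 3 is 10000 nM, from 4000 nM to 25000 nM.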

Compound 3, half-maximal inhibitory concentration: 16300 nM
The estimate for compound 3 lay 1.6-fold (0.21 log units) below the measured number, within the range that was stated.
By their numbers in this assay, from the lowest: compounds 1, 2 and 3 (each within the scatter of the next).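

In this assay, a chloro placed ortho to a large group and meta to the existing chloro group gives a 1.5-fold higher number from compound 1 to compound 3 (0.17 log units; within the scatter). Set against the bromo compound, the 2,4-dichlorophenyl group gives a 1.5-fold higher number from compound 2 to compound 3 (0.17 log units; within the scatter), so this position accepts a second chloro with no step beyond the scatter, which the halogen swap alone could not show. No available evidence bears on this result. Going by these compounds, whether an amine or a carboxylic acid at this position would move the number beyond the scatter stays open.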